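Amide variation on the shared thiophene core: benzylamino

The compounds below may be only part of what the source reports. "The series", "measured", "known", "first", "only" and "open" are said of these compounds alone.

Among the compounds with values here, compound 3 `Nc1sc(-c2ccc(F)cc2)c(-c2ccc(Cl)cc2)c1C(=O)N1CCCC1` gives 18800 nM in a functional assay on A549 cells (Homo sapiens) for cytotoxicity, read by sulforhodamine B assay, with a stated time of 72 h (on this read-out lower numbers stand for stronger inhibition and higher numbers for weaker inhibition), the highest of the three numbers so far. Compound 2 `Nc1sc(-c2ccc(F)cc2)c(-c2ccc(Cl)cc2)c1C(=O)NC1CC1` gives 3000 nM in this assay, and compound 1 `Nc1sc(-c2ccccc2)c(-c2ccc(Cl)cc2)c1C(=O)NCc1ccccc1` gives 8510 nM. Within the data shown here, the only step measured on the carbonyl carbon is a 6.3-fold higher number from compound 2 to compound 3 (0.80 log units; beyond the scatter). Compound 4 `Nc1sc(-c2ccc(F)cc2)c(-c2ccc(Cl)cc2)c1C(=O)NCc1ccccc1` differs from compound 3 by benzylamino in place of pyrrolidin-1-yl on a carbonyl carbon. Among the measured compounds shown here, no measured step covers this exact exchange; compound 1 also bears benzylamino on the carbonyl carbon, and its value in this assay sits well under that of compound 3, so a lower number is expected for compound 4. The estimate for compound 4 is 7000 nM (range 2500 nM to 20000 nM), a step of a 2.7-fold lower number from compound 3 to compound 4 (0.43 log units; beyond the scatter).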

Compound 4, half-maximal inhibitory concentration: 9950 nM
Estimate against measurement, compound 4: 1.4-fold (0.15 log units) below; the range from low to high includes it.
By their numbers in this assay, from the lowest: compound 2; then compounds 1, 4 and 3 (each within the scatter of the next, the first and the last beyond it).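

In this assay, benzylamino and pyrrolidin-1-yl on the carbonyl carbon are not separated (a 1.9-fold lower number from compound 3 to compound 4 (0.28 log units; within the scatter)). Benzyl in place of cyclopropyl on the amide-type nitrogen does separate (a 3.3-fold higher number from compound 2 to compound 4 (0.52 log units; beyond the scatter)), so among the three amides with the fluoro group, only the cyclopropylamino amide of compound 2 stands apart from the other two. Fluoro in place of hydrogen on an aromatic carbon makes no difference beyond the scatter (a 1.2-fold higher number from compound 1 to compound 4 (0.07 log units; within the scatter)). No evidence on the cause of these differences is available. Open, from the compounds shown here alone, is whether a morpholine amide, a primary amide or a cyclobutylamino amide would stand with compound 2 or with compound 3.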